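The source may report more compounds than this note shows. Statements on the series, on what has been measured and on what is new or still open speak of the compounds shown alone.

Of the compounds shown here, three that share one core have so far been tested in a functional assay on MCF7 cells (Homo sapiens) for inhibition, read by MTT assay, with a stated time of 48 h; on this read-out lower numbers stand for stronger inhibition and higher numbers for weaker inhibition. Compound 1 `COc1cc2ccc(=O)oc2cc1OCCOc1no[n+]([O-])c1S(=O)(=O)c1ccccc1` gives 3540 nM in this assay. Compound 2 `COc1cc2ccc(=O)oc2cc1OCCCOc1no[n+]([O-])c1S(=O)(=O)c1ccccc1` gives 2270 nM, and compound 3 `COc1cc2ccc(=O)oc2cc1OCCCCOc1no[n+]([O-])c1S(=O)(=O)c1ccccc1` gives 3040 nM. Compound 1 carries the highest of the three numbers, yet its gap to compound 3 and its gap to compound 2 both lie within the usual scatter of repeated measurements, so no ordering among the three can be claimed. The three differ only in the length of the chain that links the two parts of the molecule, and lengthening that chain leaves the numbers essentially where they are.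

Compound 4 `COc1cc2cc(NC(C)=O)c(=O)oc2cc1OCCOc1no[n+]([O-])c1S(=O)(=O)c1ccccc1` has not yet been measured. Set against compound 1, the difference is acetamido in place of hydrogen on an aromatic carbon. For the measured compounds named here, no measured pair shows what such an addition does on this core, so the expectation rests on the narrow spread seen among compounds 1, 2 and 3. The change is expected to shift the number little, with no clear direction and probably not beyond the scatter. The expected step is a 1.2-fold lower number from compound 1 to compound 4 (0.07 log units; within the scatter). Compound 4 is therefore expected to give about 3000 nM, most likely between 1000 nM and 9000 nM.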

Compound 4, half-maximal inhibitory concentration: 6890 nM
Estimate against measurement, compound 4: 2.3-fold (0.36 log units) below; measured number inside the range.
By their numbers in this assay, from the lowest: compounds 2, 3, 1 and 4 (each within the scatter of the next, the first and the last beyond it).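

In this assay, putting acetamido in place of hydrogen on an aromatic carbon, two atoms from the ring oxygen, gives a 1.9-fold higher number from compound 1 to compound 4 (0.29 log units; within the scatter). For the compounds shown here, this is the first measured pair for this position, and it shows that a group of 4 heavy atoms, carrying a hydrogen-bond donor and a hydrogen-bond acceptor, can stand where compound 1 has only hydrogen without a step beyond the usual scatter of repeated measurements. The step therefore supports no firm claim of weaker inhibition, and no measurement shown here offers an explanation for it.

What the compounds shown leave open is whether this position stays as undemanding with other groups on the same aromatic carbon, such as a plain amine, a carboxylic acid or a longer acylamino chain, any of which could show whether a real change is possible there. Going by these compounds alone, it is also open whether acetamido at this position gives a similar step on the compounds with the longer linking chains, compound 2 and compound 3, since the only pair read so far has the chain of compound 1.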